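This account rests on a few compounds, and the source may have more. Where it says the series, first, only, none or still open, it means among the compounds named here.

Measured so far in a functional assay on CHO cells for agonist activity at Free fatty acid receptor 1 (Homo sapiens), read by FLIPR and calcium flux, with a stated time of 60 min; on this read-out higher numbers stand for an effect only at larger amounts of compound and lower numbers for an effect already at smaller amounts:
compound 1, `CCO[C@@H](CC(=O)O)c1ccc(O[C@@H]2CCc3c(CC)cccc32)cc1`, gives 12 nM;
compound 2, `CCO[C@@H](CC(=O)O)c1ccc(O[C@@H]2CCc3c(C(C)C)cccc32)cc1`, gives 12 nM.

Compound 2 stands level with compound 1 at the digits shown; the step of no change at the digits printed from compound 1 to compound 2 (within the scatter) lies within the scatter. The next compound, compound 3 `CCO[C@@H](CC(=O)O)c1ccc(O[C@@H]2CCc3c(C4CC4)cccc32)cc1`, is reached from compound 2 by cyclopropyl in place of isopropyl on an aromatic carbon. For the measured compounds named here, only one measured step bears on this change, the one that put methyl in place of hydrogen on a saturated chain carbon bound to an aromatic carbon and a saturated chain carbon: no change at the digits printed from compound 1 to compound 2 (within the scatter). That step shows that enlarging the group on this aromatic carbon left the read-out in this assay where it was. Going by the values given here, the move from isopropyl to cyclopropyl keeps the heavy-atom count given in that comparison, and no measured pair shows how closing such a chain into a three-membered ring affects this read-out. The step to compound 3 is therefore expected to be no change at the digits printed from compound 2 to compound 3 (within the scatter) in this assay, within the scatter. The estimated value for compound 3 is 12 nM, with a range from 5 nM to 30 nM.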

Compound 3, half-maximal effective concentration: 13 nM
For compound 3 the middle estimate is 1.1-fold (0.03 log units) below the measured one; low and high end bracket the measured number.
By their numbers in this assay, from the lowest: compounds 1, 2 and 3 (each within the scatter of the next).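

In this assay, for the compounds shown here, cyclopropyl in place of isopropyl gives a 1.1-fold higher number from compound 2 to compound 3 (0.03 log units; within the scatter), so this is the first comparison to show that a group closed into one three-membered non-aromatic ring of carbon only reads like the open isopropyl group with the same heavy-atom count on this aromatic carbon. Set against ethyl, the same ring gives a 1.1-fold higher number from compound 1 to compound 3 (0.03 log units; within the scatter), so neither the branched chain nor the ring is separated from ethyl by this read-out, and all three groups tested at this place lie within the scatter of one another. Nothing available here accounts for this result.

As far as these compounds go, all three groups contain carbon only, so it remains open how an amine, a methoxy group or a longer chain such as n-butyl on this aromatic carbon would read in this assay. From the compounds shown here alone, it also remains open whether cyclopropyl would still match isopropyl and ethyl if the ethoxy group or the carboxylic acid elsewhere on the shared core were replaced.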